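This account rests on a few compounds, and the source may have more. Where it says the series, first, only, none or still open, it means among the compounds named here.

Two compounds of the shared core have numbers in an assay on isolated protein for inhibition of Retinaldehyde dehydrogenase 3 (Homo sapiens); on this read-out higher numbers stand for weaker inhibition and lower numbers for stronger inhibition. Compound 1 `Cn1ncc2c(=O)n(-c3ccccc3)c(COc3cccc(F)c3)nc21` gives 780 nM in this assay, the highest of the two numbers; compound 2 `CCC(Sc1nc2c(cnn2C)c(=O)n1-c1ccccc1)c1ccccc1` gives 119 nM, a lower number beyond the scatter. Compound 3 `Cn1ncc2c(=O)n(-c3ccccc3)c(CCc3cccc(F)c3)nc21` is not yet measured. It differs from compound 1 by 3-fluorobenzyl in place of 3-fluorophenoxy on a saturated chain carbon bound to an aromatic carbon. For the measured compounds named here, no measured pair shows this change, so nothing fixes its size; a step within the scatter, or at most a small one in either direction, is expected. For compound 3 the expected value in this assay is 700 nM, with a range from 250 nM to 2000 nM. The step of a 1.1-fold lower number from compound 1 to compound 3 (0.05 log units; within the scatter) is thus expected to stay within the scatter.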

Compound 3, half-maximal inhibitory concentration: 2500 nM
For compound 3 the middle estimate is 3.6-fold (0.55 log units) below the measured one; measured number outside the range, above it.
By their numbers in this assay, from the lowest: compound 2; then compound 1; then compound 3.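

In this assay this position is sensitive to the linking atom: 3-fluorobenzyl in place of 3-fluorophenoxy gives a 3.2-fold higher number from compound 1 to compound 3 (0.51 log units; beyond the scatter) even though both groups have 8 heavy atoms and the same aromatic ring. The counted difference is that the oxygen and its one hydrogen-bond acceptor leave and a carbon enters. Nothing at hand explains the step. Open, as far as these compounds go, is how an amine linker in place of the oxygen, or a longer chain, would read at this place. Also open, from the compounds shown here alone, is whether the fluorine matters, which an unsubstituted phenoxy would test.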